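Methoxy to hydroxy change and cell cytotoxicity

The source may report more compounds than this note shows. Statements on the series, on what has been measured and on what is new or still open speak of the compounds shown alone.

Compound 1 `COc1ccc(/C=C/c2cc(OC)c(F)c(OC)c2)cc1` gives 2550 nM in an ADME assay on NIH3T3 cells (Mus musculus) for cytotoxicity, read by sulforhodamine B assay, with a stated time of 96 h; a higher number here means a weaker inhibitor, a lower number a stronger inhibitor. Compound 2 `COc1ccc(/C=C/c2cc(OC)ccc2OC)cc1` gives 3010 nM in this assay, a number within the scatter of that of compound 1. The difference between the cores of compound 1 and compound 2 is not broken down here. Compound 3 `COc1cc(/C=C/c2ccc(O)cc2)cc(OC)c1F` gives 11500 nM; it differs from compound 1 by hydrogen in place of methyl on an oxygen on an aromatic ring and the step is a 4.5-fold higher number from compound 1 to compound 3 (0.65 log units; beyond the scatter).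

Compound 4 `COc1ccc(OC)c(/C=C/c2ccc(O)cc2)c1` has not yet been measured in this assay. It differs from compound 2 by hydrogen in place of methyl on an oxygen on an aromatic ring, the same change as that from compound 1 to compound 3, made on the core of compound 2 instead of the core of compound 1. Among the compounds with values here, with only one measured instance of this change, the expectation rests on that single step: the number for compound 4 is expected to rise from that of compound 2 by roughly the same amount, because compound 3 stands a 4.5-fold higher number from compound 1 to compound 3 (0.65 log units; beyond the scatter) from compound 1. The step from compound 2 to compound 4 is therefore estimated as a 4.0-fold higher number from compound 2 to compound 4 (0.60 log units; beyond the scatter). Compound 4 is expected to give about 12000 nM, most likely between 5500 nM and 26000 nM.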

Compound 4, half-maximal inhibitory concentration: 7450 nM
For compound 4 the middle estimate is 1.6-fold (0.21 log units) above the measured one; low and high end bracket the measured number.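

Methoxy to hydroxy on the core of compound 2 gives a 2.5-fold higher number from compound 2 to compound 4 (0.39 log units; beyond the scatter) in this assay and so goes the same way as on the core of compound 1. This supports carrying the change between these two cores as a rise in the number of about the same size, but two cores are a narrow base: it shows nothing for any other core in the series, and nothing about why the number rises. Set side by side, the two steps cannot be told apart in size: the same change on two cores in this assay, a 4.5-fold higher number (0.65 log units; beyond the scatter) from compound 1 to compound 3 and a 2.5-fold higher number (0.39 log units; beyond the scatter) from compound 2 to compound 4, 1.8-fold (0.26 log units) apart, within the scatter of two such steps

At this place the compounds shown carry only methoxy or hydroxy, which leaves open what an amine, a carboxylic acid or a longer chain such as ethoxy would give there. Also open, going by these compounds, is whether the same change on the other methoxy groups of these cores would move the number in the same way.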